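The source may report more compounds than this note shows. Statements on the series, on what has been measured and on what is new or still open speak of the compounds shown alone.

Measured so far in an ADME assay on BaF3 cells (Mus musculus) for cytotoxicity; a lower number here means that less compound is needed, a higher number that more compound is needed for the effect:

- compound 1 `O=C(NCCO)c1cc2c(Nc3ccc(OC(F)(F)F)cc3)ncnc2s1`: > 10000 nM, which is a limit of the assay
- compound 2 `COC(=O)c1cc2c(Nc3ccc(OC(F)(F)F)cc3)ncnc2s1`: > 10000 nM, which is again a limit of the assay

Compound 2 therefore stands nowhere on a numerical scale in this assay; the value given for compound 2, > 10000 nM, is a limit and not a number. Within the data shown here, the single measured step, a step that the two limits leave unreadable from compound 1 to compound 2, is of unknown size because the limit of > 10000 nM in this assay, at which 2 of the 2 values shown sit, covers both of its ends. Compound 3 `O=C(c1cc2c(Nc3ccc(OC(F)(F)F)cc3)ncnc2s1)N1CCC(O)CC1` differs from compound 2 by 4-hydroxypiperidin-1-yl in place of methoxy on a carbonyl carbon. Among the measured compounds shown here, the only measured step that bears on this change is the unreadable one, so no readable step exists to set a direction or size. In this assay compound 3 is therefore expected to remain at the limit as well, which means an expected step that the limit leaves unreadable from compound 2 to compound 3. The estimate for compound 3 is 15000 nM, with a range from 5000 nM to 50000 nM.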

Compound 3, half-maximal effective concentration: > 10000 nM
Compound 3 ended at the assay's limit; the forecaster's own chance of this, stated with the estimate: 80%; the middle value does not contradict the limit.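

In this assay compound 3 gives > 10000 nM as a limit of the assay, not a number. Among these compounds, no step among compound 1, compound 2 and compound 3 can be read, because all three sit at the same limit: the limit of > 10000 nM in this assay, at which 3 of the 3 values shown sit. The compounds shown leave open where each would fall on a numerical scale, and whether changing the group on the carbonyl carbon shifts the value at all.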